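Swapping the ring on the benzylic carbon: compound 4

The source may report more compounds than this note shows. Statements on the series, on what has been measured and on what is new or still open speak of the compounds shown alone.

Compounds measured in an assay on membranes from uterus for displacement of a labelled ligand from Angiotensin type II receptor (Sus scrofa), with a stated time of 1.5 h (on this read-out higher numbers stand for weaker inhibition and lower numbers for stronger inhibition), so far:
compound 1, `CCCCOC(=O)NS(=O)(=O)c1sc(CC(C)C)cc1-c1ccc(CN2C(=O)CN(C)C2=O)cc1`, 68.6 nM
compound 2, `CCCCOC(=O)NS(=O)(=O)c1sc(CC(C)C)cc1-c1ccc(Cc2nccs2)cc1`, 3.2 nM
compound 3, `CCCCOC(=O)NS(=O)(=O)c1sc(CC(C)C)cc1-c1ccc(Cn2ncnn2)cc1`, 16 nM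

All three share one core and differ only in the ring attached to a saturated chain carbon bound to an aromatic carbon. Compound 3 stands second highest of the three numbers: it lies beyond the scatter from both neighbours, as a 4.3-fold lower number from compound 1 to compound 3 (0.63 log units; beyond the scatter) and a 5.0-fold higher number from compound 2 to compound 3 (0.70 log units; beyond the scatter) show, while a 21-fold lower number from compound 1 to compound 2 (1.33 log units; beyond the scatter) is the largest step seen.

Compound 4, `CCCCOC(=O)NS(=O)(=O)c1sc(CC(C)C)cc1-c1ccc(CN2C(=O)N(C)C(C)(C)C2=O)cc1`, has not yet been measured. It differs from compound 3 by 3,4,4-trimethyl-2,5-dioxoimidazolidin-1-yl in place of 2H-tetrazol-2-yl on a saturated chain carbon bound to an aromatic carbon. The step that bears on this is a 4.3-fold lower number from compound 1 to compound 3 (0.63 log units; beyond the scatter), since the group that enters in compound 4 is the group of compound 1 with two extra methyls on its non-aromatic ring. Walking that step back suggests a modest rise in the number for this assay. Compound 4 is therefore expected to show a 3.8-fold higher number from compound 3 to compound 4 (0.57 log units; beyond the scatter), with an estimated value of 60 nM and a range from 20 nM to 200 nM.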

Compound 4, inhibition constant: 3.6 nM
The estimate for compound 4 lay 17-fold (1.22 log units) above the measured number; the whole stated range lies above it.
By their numbers in this assay, from the lowest: compounds 2 and 4 (each within the scatter of the next); then compound 3; then compound 1.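

In this assay, the ring on this saturated chain carbon turns out to be highly sensitive to small additions: going from 3-methyl-2,5-dioxoimidazolidin-1-yl to 3,4,4-trimethyl-2,5-dioxoimidazolidin-1-yl, which only adds methyls to the same ring, gives a 19-fold lower number from compound 1 to compound 4 (1.28 log units; beyond the scatter). A non-aromatic ring can therefore do better than the 2H-tetrazol-2-yl ring, as a 4.4-fold lower number from compound 3 to compound 4 (0.65 log units; beyond the scatter) shows, and it can match the 1,3-thiazol-2-yl ring, since a 1.1-fold higher number from compound 2 to compound 4 (0.05 log units; within the scatter) leaves the two indistinguishable. No supporting data here explain why the added methyls have so large an effect.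

The compounds shown leave open whether the 3,4-dimethyl-2,5-dioxoimidazolidin-1-yl ring, with one methyl fewer, would keep this gain. They also leave open how the 4,4-diethyl-3-methyl-2,5-dioxoimidazolidin-1-yl ring, with ethyl groups on the same ring, would compare.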